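This account rests on a few compounds, and the source may have more. Where it says the series, first, only, none or still open, it means among the compounds named here.

Measured compounds in an assay on membranes from Sf9 cells for displacement of a labelled ligand from histamine H2 receptor (Homo sapiens), read by scintillation counting, with a stated time of 60 min; a higher number here means a weaker inhibitor, a lower number a stronger inhibitor:
- compound 1 `Cc1nc(N)sc1CCCN/C(N)=N/C(=O)NCc1ccco1`: 10.5 nM
- compound 2 `Cc1nc(N)sc1CCCN/C(N)=N/C(=O)NC(C)c1ccccc1F`: 28.8 nM
- compound 3 `Cc1nc(N)sc1CCCN/C(N)=N/C(=O)Nc1ccccc1`: 3160 nM

Compound 3 gives the highest number of the three in this assay; compound 2 and compound 1 both sit far lower, and both gaps lie beyond the scatter. Going by the values given here, the only single-point step that is recorded is a 300-fold higher number from compound 1 to compound 3 (2.48 log units; beyond the scatter), a large rise on exchanging the (furan-2-yl)methyl for a plain phenyl on the amide-type nitrogen.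

Compound 4 `Cc1nc(N)sc1CCCN/C(N)=N/C(=O)NC(C)c1ccco1` reverses that exchange and adds one carbon: 1-(furan-2-yl)ethyl in place of phenyl on an amide-type nitrogen. The furan ring returns, now as a 1-(furan-2-yl)ethyl group. The recorded step from compound 1 to compound 3 bears on this directly and suggests a large fall in the number. Among the compounds with values here, the extra carbon has no measured counterpart against compound 1; compound 2, which carries a similar branched group with a different ring, gives 28.8 nM, close to compound 1. A large downward step is therefore expected in this assay: a 210-fold lower number from compound 3 to compound 4 (2.32 log units; beyond the scatter). For compound 4 the estimate is 15 nM, within 4 nM to 60 nM.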

Compound 4, inhibition constant: 31.6 nM
For compound 4 the middle estimate is 2.1-fold (0.32 log units) below the measured one; measured number inside the range.
By their numbers in this assay, from the lowest: compound 1; then compounds 2 and 4 (each within the scatter of the next); then compound 3.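

In this assay, the furan ring on a branched carbon brings the number back down by a wide margin (a 100-fold lower number from compound 3 to compound 4 (2.00 log units; beyond the scatter)), so the weak result of compound 3 does not extend to every group on this amide-type nitrogen. Methyl in place of hydrogen on the chain carbon gives the first measured change at that carbon, and it is a modest one (a 3.0-fold higher number from compound 1 to compound 4 (0.48 log units; beyond the scatter)). With that branched carbon kept, furan-2-yl in place of 2-fluorophenyl leaves the number within the scatter (a 1.1-fold higher number from compound 2 to compound 4 (0.04 log units; within the scatter)), so the two rings cannot be told apart here.

Nothing among the data explains these steps. As far as these compounds go, it remains open whether the chain carbon alone separates compound 3 from the others, a question that benzyl or 2-(furan-2-yl)ethyl on this nitrogen would address.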